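Dropping a Chloro Group: What Happens to Cell Growth?

This account rests on a few compounds, and the source may have more. Where it says the series, first, only, none or still open, it means among the compounds named here.

Among the measured compounds shown here, compound 1 `COc1ccc(-c2nc(C)c(C(=O)CSc3nc(N)c(C#N)c(-c4ccc(Cl)cc4)n3)s2)cc1` was tested in a functional assay on U-87MG ATCC cells for antiproliferative activity against U-87 MG (Homo sapiens), read by MTT assay, with a stated time of 48 h, tested at 50 uM (a higher number here means a weaker effect of the compound at the concentration tested, a lower number a stronger effect), where compound 1 gives 23.1%, the lowest of the two numbers known. Compound 2 `Cc1nc(-c2ccc(Cl)cc2)sc1C(=O)CSc1nc(-c2ccccc2)c(C#N)c(=O)[nH]1` gives 41.6% in this assay, a value higher than that of compound 1 by more than the usual scatter. Compound 3 `COc1ccc(-c2nc(C)c(C(=O)CSc3nc(N)c(C#N)c(-c4ccccc4)n3)s2)cc1` is not yet measured. It differs from compound 1 in one place: hydrogen in place of chloro on an aromatic carbon. For the measured compounds named here, no measured pair shows this change on its own, so the size of the step can only be estimated. The step of a number 6.9 percentage points higher from compound 1 to compound 3 (within the scatter) is expected to be small, toward a slightly higher number. Compound 3 is expected to give 30%, between 15% and 50%.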

Compound 3, a percentage reported as activity, at one concentration (the size of the read-out at that concentration, not a potency): 16.5%
For compound 3 the middle estimate is 13.5 percentage points above the measured one; low and high end bracket the measured number.
By their numbers in this assay, from the lowest: compounds 3 and 1 (each within the scatter of the next); then compound 2.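

In this assay, going from 4-chlorophenyl to phenyl gives a small step (a number 6.6 percentage points lower from compound 1 to compound 3 (within the scatter)). Among the compounds shown here, this is the first direct look at this change on its own, and it shows that the chloro group at this place is not needed for the effect seen at the concentration tested. For this pair, a bare hydrogen serves about as well.

From the compounds shown here alone, how a fluoro group or a carboxylic acid at the same place would read remains open. No measurement here explains why the two compounds read so alike.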